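The source may report more compounds than this note shows. Statements on the series, on what has been measured and on what is new or still open speak of the compounds shown alone.

Working notes on the benzoxazole sulfonamide series in an assay on isolated protein for inhibition of malate dehydrogenase, mitochondrial (Sus scrofa), with stated times of 45 min and 30 min; a higher number here means a weaker inhibitor, a lower number a stronger inhibitor.

Compound 1, `Cc1ccccc1S(=O)(=O)Nc1ccc2oc(-c3ccccc3)nc2c1`, gives in this assay a value that is a limit of the assay and not a number, > 63000 nM. Compound 3, `Cc1cccc(S(=O)(=O)Nc2ccc3oc(-c4ccccc4)nc3c2)c1`, likewise gives only a limit, > 63000 nM. The step that the two limits leave unreadable from compound 1 to compound 3, 3-methylphenyl in place of 2-methylphenyl on a sulfonyl sulfur, cannot be read because both ends sit at the limit of > 63000 nM in this assay, at which 3 of the 3 values shown sit.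

Compound 2, `O=S(=O)(Nc1ccc(-c2nc3ccccc3o2)cc1)c1ccccc1C(F)(F)F`, also stands only at a limit in this assay, > 63000 nM; no measured number places it anywhere within the range of the assay.

Compound 4, `O=S(=O)(Nc1ccc(-c2nc3ccccc3o2)cc1)c1ccccc1Cl`, is not yet measured. The change from compound 2 is chloro in place of trifluoromethyl on an aromatic carbon, ortho to a large group. Within the data shown here, no measured step touches this change, and the only readable fact is the limit of > 63000 nM in this assay, at which 3 of the 3 values shown sit, at which every value so far sits. Compound 4 is therefore expected to stay at that limit as well, giving 80000 nM with a range of 25000 nM to 300000 nM. The step from compound 2 to compound 4 is estimated as a step that the limit leaves unreadable from compound 2 to compound 4, that is, no change beyond the scatter.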

Compound 4, half-maximal inhibitory concentration: > 63000 nM
Compound 4: a limit, no number; the forecaster's own chance of this, stated with the estimate: 85%; the middle value is on the limit's open side.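

No new step can be read between compound 2 and compound 4, because both stand at a limit of the assay and not at a number: the limit of > 63000 nM in this assay, at which 4 of the 4 values shown sit.

The compounds shown leave open whether any change on the shared core gives a measured number in this assay at all.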